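The compounds below may be only part of what the source reports. "The series", "measured", "known", "first", "only" and "open" are said of these compounds alone.

In a functional assay on FM3A cells (Mus musculus) for antiproliferative activity (a higher number here means a weaker inhibitor, a lower number a stronger inhibitor), compound 3 `COc1cc(C(=O)c2sc(-c3ccccc3)cc2N)cc(OC)c1OC` gives 13 nM as the lowest of three numbers. Compound 1 `COc1cc(C(=O)c2sc(-c3ccc([N+](=O)[O-])cc3)cc2N)cc(OC)c1OC` gives 64 nM and compound 2 `COc1cc(C(=O)c2sc(-c3ccc(Cl)cc3)cc2N)cc(OC)c1OC` gives 90 nM and these two lie within the scatter of each other. Compound 4 `COc1cc(C(=O)c2sc(-c3ccncc3)cc2N)cc(OC)c1OC` differs from compound 3 by one swap (pyridin-4-yl in place of phenyl on an aromatic carbon), pyridin-4-yl in place of phenyl on an aromatic carbon next to the ring sulfur. For the measured compounds named here, two measured steps bear on it: hydrogen in place of nitro gives a 4.9-fold lower number from compound 1 to compound 3 (0.69 log units; beyond the scatter) and hydrogen in place of chloro gives a 6.9-fold lower number from compound 2 to compound 3 (0.84 log units; beyond the scatter) and both are modest. Neither changes an atom of the ring itself, so they guide only loosely. A modest rise in this assay is still expected, with a 3.8-fold higher number from compound 3 to compound 4 (0.59 log units; beyond the scatter) as the estimated step. For compound 4 the expected value is 50 nM with an estimated range of 15 nM to 170 nM in this measurement.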

Compound 4, half-maximal inhibitory concentration: 150 nM
Beside the measured number, compound 4's estimate is 3.0-fold (0.48 log units) below it; the range from low to high includes it.
By their numbers in this assay, from the lowest: compound 3; then compounds 1, 2 and 4 (each within the scatter of the next, the first and the last beyond it).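

In this assay, for the compounds shown here, this is the first change here that alters an atom of the aromatic ring itself, replacing a ring carbon with nitrogen, and it gives a 12-fold higher number from compound 3 to compound 4 (1.06 log units; beyond the scatter). Set against the substituted phenyl compounds, it gives a 2.3-fold higher number from compound 1 to compound 4 (0.37 log units; beyond the scatter) and a 1.7-fold higher number from compound 2 to compound 4 (0.22 log units; within the scatter), so the unsubstituted phenyl of compound 3 remains the lowest of the four. Nothing measured here accounts for the rise. As far as these compounds go, whether a phenyl carrying a methoxy group or an amine, or a thiophene ring at this place, would stay as low as compound 3 remains open.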